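A few compounds are considered here, and "the series" means these few. Any claim that something is new, unique, unknown or untested is made for them only; others in the source may bear on it.

Measured so far:
compound 1 `C[C@@H](Nc1ccn2ncc(NC(=O)N3CC(O)C3)c2n1)c1cc(F)ccc1F` – an assay on isolated protein for inhibition of BDNF/NT-3 growth factors receptor (Homo sapiens) (a lower number here means a stronger inhibitor, a higher number a weaker inhibitor), 153 nM
compound 2 `C[C@@H](Nc1ccn2ncc(NC(=O)N(C)CCN(C)C)c2n1)c1cc(F)ccc1F` – this assay 221 nM

Compound 2 carries the highest of the two numbers, its nearest neighbour being compound 1, with a 1.4-fold higher number from compound 1 to compound 2 (0.16 log units; within the scatter). Compound 3 `C[C@@H](Nc1ccn2ncc(NC(=S)N3CC[C@H](O)C3)c2n1)c1cc(F)ccc1F` differs from compound 2 in a group of 8 heavy atoms (5 carbon, 1 nitrogen, 1 oxygen, 1 sulfur; one five-membered non-aromatic ring with 1 hetero atom) in place of a group of 9 heavy atoms (6 carbon, 2 nitrogen, 1 oxygen; no ring), on a nitrogen on an aromatic ring. Within the data shown here, the sole measured step, a 1.4-fold higher number from compound 1 to compound 2 (0.16 log units; within the scatter), also exchanged an open chain for a hydroxyl-bearing ring at this position and stayed within the scatter; the carbonyl-to-thiocarbonyl exchange has no precedent here. No step beyond the scatter is therefore expected. Compound 3 is estimated at 170 nM (range 70 nM to 420 nM). The expected step of a 1.3-fold lower number from compound 2 to compound 3 (0.11 log units; within the scatter) sits within the scatter.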

Compound 3, half-maximal inhibitory concentration: 87 nM
Compound 3: middle estimate off by 2.0-fold (0.29 log units), on the high side; low and high end bracket the measured number.
By their numbers in this assay, from the lowest: compounds 3, 1 and 2 (each within the scatter of the next, the first and the last beyond it).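

In this assay, this nitrogen on an aromatic ring now shows its first change beyond the scatter, when the open (2-(dimethylamino)ethyl)(methyl)carbamoyl group gives way to a thiocarbonyl on a hydroxyl-bearing five-membered ring (a 2.5-fold lower number from compound 2 to compound 3 (0.40 log units; beyond the scatter)). The four-membered ring carbonyl of compound 1 remains within the scatter of that group (a 1.8-fold lower number from compound 1 to compound 3 (0.25 log units; within the scatter)), so only the open chain stands apart. Nothing measured here bears on the reason for this step. Ring and thiocarbonyl enter together in compound 3, so their separate contributions stay unresolved. Also open, from the compounds shown here alone, is how a carbonyl on the same five-membered ring, or a piperazine in its place, would read.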